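Swapping the aryl group on the ring nitrogen in compound 2

This account rests on a few compounds, and the source may have more. Where it says the series, first, only, none or still open, it means among the compounds named here.

The shared core carries an amide joined to a six-membered ring with two nitrogens, the second of which bears an aromatic group. Compound 1 `CCCc1nc(-c2ccc(OC)c(OC)c2)c(C(=O)N2CCN(c3cccc(Cl)c3)CC2)o1` was recorded in a functional assay on HL-60 cells (Homo sapiens) for inhibition, read by MTT assay, with a stated time of 72 h (a higher number here means a weaker inhibitor, a lower number a stronger inhibitor), as "not active" (no number reported), and compound 2 `CC(=O)c1ccc(N2CCN(C(=O)c3oc(C)nc3-c3ccccc3)CC2)cc1` was likewise recorded as "not active" (no number reported), so no number stands for either. Among the measured compounds shown here, compound 3 `COc1cc(OC)cc(N2CCN(C(=O)c3onc(C)c3-c3ccc(F)cc3)CC2)c1` is the only one with a value: in this assay compound 3 gives 475 nM. Compound 2 therefore stands below the measurable range, while compound 3 shows that the general arrangement can inhibit.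

Compound 4 `Cc1ccc(C)c(N2CCN(C(=O)c3oc(C)nc3-c3ccccc3)CC2)c1` is not yet measured. It differs from compound 2 in one place: 2,5-dimethylphenyl in place of 4-acetylphenyl on an amine nitrogen in a ring. For the measured compounds named here, two of the three measured neighbours gave no number, and there is no measured step to guide the size of the change, so the expectation is for weak inhibition, with a fair chance that compound 4 again yields no number rather than a value. If a number appears, compound 4 is estimated at 6000 nM, within a range from 600 nM to 60000 nM.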

Compound 4, half-maximal inhibitory concentration: 31.3 nM
Estimate against measurement, compound 4: 190-fold (2.28 log units) above; measured number below the stated range.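

Among the compounds shown here, compound 2 has no number in this assay, so no step to compound 4, at 31.3 nM, can be read. Nothing shown gives a reason for this result. Which part of the 2,5-dimethylphenyl group goes with this inhibition remains open, as does whether it would hold on other cores.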